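A few compounds are considered here, and "the series" means these few. Any claim that something is new, unique, unknown or untested is made for them only; others in the source may bear on it.

Measured compounds:
Compound 1, `O=C(NCc1ccncc1)Nc1ccc(S(=O)(=O)c2ccccc2Cl)cc1`, gives 79 nM in an assay on isolated protein for activation of Nicotinamide phosphoribosyltransferase (Homo sapiens); a lower number here means that less compound is needed, a higher number that more compound is needed for the effect.
Compound 2, `CNS(=O)(=O)c1ccc(NC(=O)NCc2ccncc2)cc1`, gives 3230 nM in this assay.

Among the measured compounds shown here, compound 2 holds the highest of these two numbers; its nearest neighbour is compound 1, and the step of a 41-fold higher number from compound 1 to compound 2 (1.61 log units; beyond the scatter) is the only measured step in this set. Compound 3, `O=C(NCc1ccncc1)Nc1ccc(S(=O)(=O)c2ccc(Cl)cc2)cc1`, differs from compound 2 by 4-chlorophenyl in place of methylamino on a sulfonyl sulfur. This change bears directly on that step, since it again exchanges the methylamino group on the sulfonyl sulfur for a chlorine-bearing phenyl ring, though with the chlorine now at the 4-position rather than the 2-position. The large step from compound 1 to compound 2 in this assay is therefore expected to be largely reversed, and a large step downward is expected in this assay for compound 3, close to a 29-fold lower number from compound 2 to compound 3 (1.47 log units; beyond the scatter). Compound 3 is accordingly estimated at 110 nM in this assay, with a range from 30 nM to 450 nM.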

Compound 3, half-maximal effective concentration: 126 nM
Compound 3: middle estimate off by 1.1-fold (0.06 log units), on the low side; measured number inside the range.
By their numbers in this assay, from the lowest: compounds 1 and 3 (each within the scatter of the next); then compound 2.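

In this assay, the large step of a 26-fold lower number from compound 2 to compound 3 (1.41 log units; beyond the scatter) shows that the return from the methylamino compound to a low number does not depend on a single chlorine placement: it occurs with 4-chlorophenyl on the sulfonyl sulfur as well as with 2-chlorophenyl. The exchange of one chlorophenyl group for the other gives a 1.6-fold higher number from compound 1 to compound 3 (0.20 log units; within the scatter), so these two placements of the chlorine are not separated by this measurement. Nothing available gives a reason for the size of either step.

From the compounds shown here alone, whether the chlorine is needed at all remains open, a question that a plain phenyl ring on the sulfonyl sulfur would address. Going by these compounds, it is also open whether a cyclohexyl ring or a simple butyl chain could take the place of the aromatic ring.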